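Benzamide series: HDAC6 inhibition, step from compound 2 to compound 4

The source may hold more compounds than are shown below. What is called first, only, known or untested is meant among the compounds shown, and "the series" means these compounds.

Measured compounds:
compound 1 `CC(=O)N1C(NCc2ccc(C(=O)Nc3ccccc3N)cc2)=NC(=O)C1Cc1ccccc1`, > 20000 nM
compound 2 `Nc1cc(C(=O)OCc2ccccc2)ccc1NC(=O)c1ccc(CNc2nccc(-c3cccnc3)n2)cc1`, > 20000 nM
compound 3 `Nc1ccccc1NC(=O)c1ccc(CNC2=NC[C@H](c3ccccc3)S2)cc1`, "not determined" (no result reported)

In an assay on isolated protein for inhibition of protein deacetylase HDAC6 (Homo sapiens), read by fluorescence, with stated times of 3 h and 60 min (a higher number here means a weaker inhibitor, a lower number a stronger inhibitor), compound 1 gives > 20000 nM, a limit of the assay and not a number. In this assay compound 2 gives > 20000 nM, again a limit and not a number. For compound 3 this assay gives "not determined" (no result reported). Compound 2 therefore stands at the upper boundary of what this assay reports; (the limit of > 20000 nM in this assay, at which 2 of the 3 values shown sit), so nothing among the shown values separates compound 2 from compound 1, and no ordering can be read from them.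

The unmeasured compound 4 `Nc1cc(-c2ccccc2)ccc1NC(=O)c1ccc(CNc2nccc(-c3cccnc3)n2)cc1` differs from compound 2 by phenyl in place of benzyloxycarbonyl on an aromatic carbon. Among the measured compounds shown here, no measured pair isolates this change, so its effect in this assay is unknown. Given that compound 2 sits at the limit > 20000 nM, the step from compound 2 to compound 4 is expected to be small or not resolvable, most likely again a limit. Compound 4 is estimated at 20000 nM, in the range 5000 nM to 60000 nM, which means an expected step of a number no higher from compound 2 to compound 4 (the limit leaves the size open).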

Compound 4, half-maximal inhibitory concentration: > 20000 nM
Compound 4 ended at the assay's limit; the forecaster's own chance of this, stated with the estimate: 70%; the middle value sits exactly at the limit.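

Among the compounds shown here, compound 2 and compound 4 both stand at a limit of this assay, not at a number, so no step between them can be read for phenyl in place of benzyloxycarbonyl. The compounds shown leave open what this change does in this assay and how the compounds rank there.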